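Adding a chloro group to compound 1

A few compounds are considered here, and "the series" means these few. Any claim that something is new, unique, unknown or untested is made for them only; others in the source may bear on it.

In a functional assay on MCF7 cells (Homo sapiens) for cytotoxicity, read by MTT assay, with a stated time of 48 h (on this read-out higher numbers stand for weaker inhibition and lower numbers for stronger inhibition), compound 1 (`Cc1noc2c(C(c3ccccc3)c3c(-c4ccccc4)c[n+]([O-])c4c(C)noc34)c(-c3ccccc3)c[n+]([O-])c12`) gives 31.9 ug/mL while compound 2 (`Cc1ccccc1C(c1c(-c2ccccc2)c[n+]([O-])c2c(C)noc12)c1c(-c2ccccc2)c[n+]([O-])c2c(C)noc12`) gives 60.7 ug/mL and these two numbers lie within the scatter of each other. Among the measured compounds shown here, compound 1 therefore stands level with the only other measured compound. Compound 3 (`Cc1noc2c(C(c3ccc(Cl)cc3)c3c(-c4ccccc4)c[n+]([O-])c4c(C)noc34)c(-c3ccccc3)c[n+]([O-])c12`) has not yet been measured and carries one change from compound 1 (chloro in place of hydrogen on an aromatic carbon): chloro in place of hydrogen on an aromatic carbon, which turns phenyl to 4-chlorophenyl. For the measured compounds named here, the one measured step that bears on this also replaces hydrogen on an aromatic carbon, with methyl as the new group. It amounts to a 1.9-fold higher number from compound 1 to compound 2 (0.28 log units; within the scatter) and offers no sign of a real shift. Methyl is not chloro, so this single step is only a loose guide, and no measured compound here carries chloro. On that thin basis, no step beyond the scatter is expected in this assay for this change. The estimated step is a 1.1-fold higher number from compound 1 to compound 3 (0.04 log units; within the scatter) and it rests on that one comparison. For compound 3 the estimated value is 35 ug/mL with an expected range from 15 ug/mL to 80 ug/mL as its likely span.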

Compound 3, half-maximal inhibitory concentration: 74.3 ug/mL
Compound 3: middle estimate off by 2.1-fold (0.33 log units), on the low side, and the stated range covers the measured number.
By their numbers in this assay, from the lowest: compounds 1, 2 and 3 (each within the scatter of the next, the first and the last beyond it).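

In this assay, among the compounds shown here, chloro on the phenyl group, which turns it into 4-chlorophenyl, gives a 2.3-fold higher number from compound 1 to compound 3 (0.37 log units; beyond the scatter) and so is the first single change in this small set to pass the usual scatter, a modest move toward weaker inhibition. Replacing hydrogen on this ring therefore need not leave the number unchanged, although the 2-methylphenyl group of compound 2 gives only a 1.9-fold higher number from compound 1 to compound 2 (0.28 log units; within the scatter), and the two substituted compounds cannot be told apart, with a 1.2-fold higher number from compound 2 to compound 3 (0.09 log units; within the scatter) as the step between them. No measurement here offers an explanation for the chloro step.

As far as these compounds go, with only methyl and chloro tried on this ring, it remains open whether a group such as fluoro, methoxy or an amine would stay level with compound 1 or give a larger step. The same chloro group at another place on the ring is also untested among the compounds shown, so these results cannot say whether the modest step depends on its position.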